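Three hydroxyphenyl groups on one core, and a fourth arrangement

The source may report more compounds than this note shows. Statements on the series, on what has been measured and on what is new or still open speak of the compounds shown alone.

Compound 1 `Oc1ccc(-c2cc(-c3ccccc3O)cc(-c3cccc(O)c3)n2)cc1`: 650 nM
Compound 2 `Oc1ccc(-c2cc(-c3ccccc3O)cc(-c3ccccc3O)n2)cc1`: 960 nM
Compound 3 `Oc1cccc(-c2cc(-c3ccccc3O)cc(-c3ccccc3O)n2)c1`: 5760 nM

In a functional assay on T47D cells (Homo sapiens) for cytotoxicity, read by CCK-8 assay, with a stated time of 4 days (on this read-out lower numbers stand for stronger inhibition and higher numbers for weaker inhibition), compound 1 gives 650 nM, the lowest of the three numbers; compound 2 sits a 1.5-fold higher number from compound 1 to compound 2 (0.17 log units; within the scatter), and compound 3 sits an 8.9-fold higher number from compound 1 to compound 3 (0.95 log units; beyond the scatter). Between the other two, a 6.0-fold higher number from compound 2 to compound 3 (0.78 log units; beyond the scatter).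

Compound 4 `Oc1ccc(-c2cc(-c3ccc(O)cc3)nc(-c3cccc(O)c3)c2)cc1` differs from compound 1 in one place: 4-hydroxyphenyl in place of 2-hydroxyphenyl on an aromatic carbon. The measured steps bearing on it all concern exchanges of one hydroxyphenyl for another on the shared core. Trading a 4-hydroxyphenyl for a 2-hydroxyphenyl cost the most, as an 8.9-fold higher number from compound 1 to compound 3 (0.95 log units; beyond the scatter) shows, whereas a 3-hydroxyphenyl for a 2-hydroxyphenyl hardly moved the number, as a 1.5-fold higher number from compound 1 to compound 2 (0.17 log units; within the scatter) shows. Compound 4 runs the costly exchange in reverse, though at a different place on the core, the one opposite the ring nitrogen. On that basis a lower number is expected for compound 4 in this assay, a step of about a 2.2-fold lower number from compound 1 to compound 4 (0.34 log units; beyond the scatter), which points to an estimated 300 nM, within a range of 120 nM to 900 nM.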

Compound 4, half-maximal inhibitory concentration: 4470 nM
Beside the measured number, compound 4's estimate is 15-fold (1.17 log units) below it, and the stated range ends below it.
By their numbers in this assay, from the lowest: compounds 1 and 2 (each within the scatter of the next); then compounds 4 and 3 (each within the scatter of the next).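

At the place opposite the ring nitrogen, where compounds 1, 2 and 3 all carry 2-hydroxyphenyl, the step to 4-hydroxyphenyl raises the number in this assay, with a 6.9-fold higher number from compound 1 to compound 4 (0.84 log units; beyond the scatter). The earlier compounds shown here showed that the same two groups matter at another place on the core, where 2-hydroxyphenyl in place of 4-hydroxyphenyl gave an 8.9-fold higher number from compound 1 to compound 3 (0.95 log units; beyond the scatter); here the exchange runs the other way and the number still rises, so the effect of this exchange depends on where it is made, and compound 1 keeps the lower number in both steps. No measurement at hand explains this dependence on place.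

The compounds shown leave open how 3-hydroxyphenyl would fare at this place. They also leave open whether a 2-methoxyphenyl or a 2-aminophenyl could stand in for 2-hydroxyphenyl there.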